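From an Isopropylpyrazole to a Lactam-Bearing Bicyclic Group

A few compounds are considered here, and "the series" means these few. Any claim that something is new, unique, unknown or untested is made for them only; others in the source may bear on it.

Compound 1 `CC(C)n1cc(-c2cc(C(O)(C(F)(F)F)C(F)(F)F)cnc2N2CCN(S(=O)(=O)c3ccc(N)nc3)CC2)cn1` was tested in an ADME assay (liver) for metabolic stability, with Liver microsome (Homo sapiens) as the target, using microsomes and NADPH, with a stated time of 30 min, tested at 1 uM (a lower number here means slower removal, a higher number faster removal of the compound), where compound 1 gives 38 mL.min-1.g-1. Among the numbers shown, compound 1 sits at the low end of the two plain values, with compound 3 `Nc1ccc(S(=O)(=O)N2CCN(c3ncc(C(O)(C(F)(F)F)C(F)(F)F)cc3-c3ccc4sccc4c3)CC2)cn1` at 48 mL.min-1.g-1 lying within the scatter of it. Compound 2 `Nc1ccc(S(=O)(=O)N2CCN(c3ncc(C(O)(C(F)(F)F)C(F)(F)F)cc3-c3ccoc3)CC2)cn1` gives < 14 mL.min-1.g-1 in this assay, which is a limit of the assay rather than a number. Compound 4 `Nc1ccc(S(=O)(=O)N2CCN(c3ncc(C(O)(C(F)(F)F)C(F)(F)F)cc3-c3ccc4c(c3)CC(=O)N4)CC2)cn1` differs from compound 1 by a group of 10 heavy atoms (8 carbon, 1 nitrogen, 1 oxygen; one five-membered non-aromatic ring with 1 hetero atom, one six-membered aromatic ring of carbon only) in place of a group of 8 heavy atoms (6 carbon, 2 nitrogen; one five-membered aromatic ring with 2 hetero atoms), on an aromatic carbon. Two measured steps from compound 1 bear on this change: an at least 2.7-fold lower number from compound 1 to compound 2 (0.43 log units; beyond the scatter), and a 1.3-fold higher number from compound 1 to compound 3 (0.10 log units; within the scatter). Between the two replacement groups there is an at least 3.4-fold higher number from compound 2 to compound 3 (0.53 log units; beyond the scatter). Changing the group at this carbon has so far either left the number where it was or lowered it, and a similar outcome is expected here. The step of a 1.5-fold lower number from compound 1 to compound 4 (0.18 log units; within the scatter) is the expected change. Compound 4 is therefore expected to give 25 mL.min-1.g-1, with a range from 10 mL.min-1.g-1 to 60 mL.min-1.g-1.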

Compound 4, intrinsic clearance in microsomes: < 14 mL.min-1.g-1
Compound 4: a limit, no number; the forecaster's own chance of this, stated with the estimate: 25%; at least 1.7-fold (0.25 log units) between middle value and limit.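

In this assay compound 4 gives < 14 mL.min-1.g-1, which is a limit of the assay and not a number. For the compounds shown here, with an at least 2.7-fold lower number from compound 1 to compound 4 (0.43 log units; beyond the scatter) and an at least 3.4-fold lower number from compound 3 to compound 4 (0.53 log units; beyond the scatter), this carbon now shows that a group with two rings can also give a low number, whereas the only low value before came from the single-ring furan-3-yl group, and the two-ring 1-benzothiophen-5-yl group of compound 3 did not give one. The step between compound 2 and compound 4 cannot be read, because both stand at the same limit: the limit of < 14 mL.min-1.g-1 in this assay, at which 2 of the 4 values shown sit.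

The compounds shown leave open what the actual numbers of compound 2 and compound 4 are. They also leave open whether the closed lactam ring matters, which a phenyl group carrying an open-chain acetamide at this carbon would help to answer.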